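A few compounds are considered here, and "the series" means these few. Any claim that something is new, unique, unknown or untested is made for them only; others in the source may bear on it.

Compound 1 `COc1ccc(-c2cn3ccnc3c(-c3ccc4ncn(C5CCCCC5)c4c3)n2)cc1`: 80%
Compound 2 `O=Cc1ccc(-c2cn3ccnc3c(-c3ccc4ncn(C5CCCCC5)c4c3)n2)cc1`: 45.5%
Compound 3 `c1cn2cc(-c3ccsc3)nc(-c3ccc4ncn(C5CCCCC5)c4c3)c2n1`: 5.56%

All numbers come from a functional assay on Hs-578T cells (Homo sapiens) for inhibition, read by sulforhodamine B assay, with a stated time of 48 h, tested at 10 uM; on this read-out higher numbers stand for more inhibition at the one concentration tested (going by the name of the read-out) and lower numbers for less inhibition. Compound 3 stands lowest of the three, with compound 2 nearest and compound 1 furthest away, both gaps beyond the scatter. Compound 4 `COc1ccccc1-c1cn2ccnc2c(-c2ccc3ncn(C4CCCCC4)c3c2)n1` is not yet measured; it differs from compound 3 by 2-methoxyphenyl in place of thiophen-3-yl on an aromatic carbon. Among the measured compounds shown here, the steps that bear on this change are a number 74.4 percentage points lower from compound 1 to compound 3 (beyond the scatter) and a number 39.9 percentage points lower from compound 2 to compound 3 (beyond the scatter), both large and both falling toward the thiophen-3-yl compound. The move to compound 4 runs the other way, though with 2-methoxyphenyl rather than 4-methoxyphenyl, so a large rise in this assay is expected. Compound 4 is estimated at 55%, range 25% to 85%. The expected step is a number 49.4 percentage points higher from compound 3 to compound 4 (beyond the scatter).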

Compound 4, a percentage reported as inhibition, at one concentration (the size of the read-out at that concentration, not a potency): 15.8%
Estimate against measurement, compound 4: 39.2 percentage points above, and the stated range ends above it.
By their numbers in this assay, from the lowest: compound 3; then compound 4; then compound 2; then compound 1.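

In this assay the place of the methoxy group on the phenyl ring matters: changing 4-methoxyphenyl to 2-methoxyphenyl gives a number 64.2 percentage points lower from compound 1 to compound 4 (beyond the scatter) and so loses most of the inhibition. With a number 10.2 percentage points higher from compound 3 to compound 4 (beyond the scatter) and a number 29.7 percentage points lower from compound 2 to compound 4 (beyond the scatter) as the other steps, 2-methoxyphenyl stands above thiophen-3-yl but below 4-formylphenyl, so a methoxyphenyl group as such does not secure a high number. Nothing measured here explains these differences.

Open, from the compounds shown here alone, is where 3-methoxyphenyl would stand against the 2-methoxyphenyl and 4-methoxyphenyl groups. Also open, going by these compounds, is how a phenyl ring carrying an amine or a carboxylic acid would compare with 4-formylphenyl.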